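Dimethoxy groups on the sulfonyl of compound 2

This account rests on a few compounds, and the source may have more. Where it says the series, first, only, none or still open, it means among the compounds named here.

Measured compounds:
compound 1, `CC(C)Cn1c(N)nc2c1c(=O)n(CC1CC1)c(=O)n2CC1CC1` — 12%
compound 2, `Nc1nc2c(c(=O)n(CC3CC3)c(=O)n2CC2CC2)n1S(=O)(=O)c1ccccc1` — 13%

In an assay on isolated protein with dual specificity calcium/calmodulin-dependent 3',5'-cyclic nucleotide phosphodiesterase 1B (Bos taurus) as the target, tested at 100 uM (on this read-out lower numbers stand for less inhibition and higher numbers for more inhibition at the one concentration tested (going by the name of the read-out)), compound 1 gives 12% and compound 2 gives 13%. Among the measured compounds shown here, the one measured step, a number 1 percentage points higher from compound 1 to compound 2 (within the scatter), lies within the scatter, so no order between the two compounds can be read from these numbers. Compound 2 holds the higher of the two numbers, with compound 1 nearest, within the scatter.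

Compound 3, `COc1ccc(S(=O)(=O)n2c(N)nc3c2c(=O)n(CC2CC2)c(=O)n3CC2CC2)cc1OC`, differs from compound 2 by 3,4-dimethoxyphenyl in place of phenyl on a sulfonyl sulfur. For the measured compounds named here, no measured step touches the group on the sulfonyl sulfur, so nothing measured bears directly on this change; the only measured step concerns the aromatic nitrogen and was within the scatter. With both measured numbers low, compound 3 is expected to show a step of a number 1 percentage points higher from compound 2 to compound 3 (within the scatter) that stays within the scatter. For compound 3 the estimate in this assay is 14%, with a range from 2% to 28%.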

Compound 3, a percentage reported as inhibition, at one concentration (the size of the read-out at that concentration, not a potency): 56%
Compound 3: the middle estimate sits 42 percentage points below what was measured; measured number outside the range, above it.
By their numbers in this assay, from the lowest: compounds 1 and 2 (each within the scatter of the next); then compound 3.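

In this assay, the group on the sulfonyl sulfur turns out to matter: 3,4-dimethoxyphenyl in place of phenyl gives a number 43 percentage points higher from compound 2 to compound 3 (beyond the scatter), the only step shown that lies beyond the scatter. Compound 1 and compound 2 sat within the scatter of each other, so they gave no sign that this read-out could move on the shared core; compound 3 shows that it can, through a change on the sulfonyl aryl group alone. Nothing shown gives a reason for this step.

As far as these compounds go, the two methoxy groups enter together, so it remains open whether a single methoxy group would give a similar step, or whether a hydroxyl, a chlorine or an amine on the phenyl ring would do the same. From the compounds shown here alone, with a single concentration tested, the potency of compound 3 also remains open.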